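From pyridin-4-yl to 4-methylpiperazin-1-yl: an open step

The compounds below may be only part of what the source reports. "The series", "measured", "known", "first", "only" and "open" are said of these compounds alone.

In a functional assay on A549 cells (Homo sapiens) for inhibition, read by MTT assay, with a stated time of 72 h (a higher number here means a weaker inhibitor, a lower number a stronger inhibitor), compound 1 `Cc1ccc(-c2cc(C(=O)N3CCC4(CC3)CC(=O)c3nn(C(C)(C)C)cc3O4)c3ccccc3n2)cc1` gives 5300 nM, compound 2 `COc1ccc(-c2cc(C(=O)N3CCC4(CC3)CC(=O)c3nn(C(C)(C)C)cc3O4)c3ccccc3n2)cc1` gives 3740 nM, and compound 3 `CC(C)(C)n1cc2c(n1)C(=O)CC1(CCN(C(=O)c3cc(-c4ccncc4)nc4ccccc34)CC1)O2` gives 550 nM, the lowest of the three. Swapping methyl for methoxy gives only a 1.4-fold lower number from compound 1 to compound 2 (0.15 log units; within the scatter). Changing the whole group matters more: a 9.6-fold lower number from compound 1 to compound 3 (0.98 log units; beyond the scatter) and a 6.8-fold lower number from compound 2 to compound 3 (0.83 log units; beyond the scatter). Compound 4 `CN1CCN(c2cc(C(=O)N3CCC4(CC3)CC(=O)c3nn(C(C)(C)C)cc3O4)c3ccccc3n2)CC1` carries 4-methylpiperazin-1-yl in place of pyridin-4-yl on an aromatic carbon. Among the compounds with values here, no measured compound has a non-aromatic ring there, so these steps show only that this place can respond, and they guide loosely. A modest move toward a higher number is expected, a 2.4-fold higher number from compound 3 to compound 4 (0.37 log units; beyond the scatter). For compound 4 the estimated value is 1300 nM, with an expected range of 300 nM to 5500 nM.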

Compound 4, half-maximal inhibitory concentration: > 10000 nM
Compound 4: only a limit was reported; the forecaster's own chance of this, stated with the estimate: 5%; middle value at least 7.6-fold (0.88 log units) away from the limit.
By their numbers in this assay, from the lowest: compound 3; then compounds 2 and 1 (each within the scatter of the next). At a limit, above all of these: compound 4.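

In this assay compound 4 reaches only a limit, not a number: the limit of > 10000 nM in this assay, at which 1 of the 4 values shown sits.

Moving from an aromatic ring to the non-aromatic 4-methylpiperazin-1-yl at this place gives an at least 18-fold higher number from compound 3 to compound 4 (1.25 log units; beyond the scatter) and also an at least 2.6-fold higher number from compound 2 to compound 4 (0.42 log units; beyond the scatter) so this position can lose much of what pyridin-4-yl gained. Against 4-methylphenyl the step is an at least 1.8-fold higher number from compound 1 to compound 4 (0.27 log units; that floor lies within the scatter) and settles no order.

On these data alone, how far compound 4 lies beyond its limit stays unknown. Also open, as far as these compounds go, is whether the loss comes from leaving an aromatic ring or from this particular ring: morpholine, piperidine or an open-chain dimethylamino group at this place could separate the two.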